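A few compounds are considered here, and "the series" means these few. Any claim that something is new, unique, unknown or untested is made for them only; others in the source may bear on it.

The study concerns four compounds built on two closely related cores. Compound 1 `COc1cc2c(cc1OC)C(c1ccc([N+](=O)[O-])cc1)=NN=C(S)C2` and compound 2 `COc1cc2c(cc1OC)C(c1ccc(Cl)cc1)=NN=C(S)C2` share one core, while compound 3 `COc1cc2c(cc1OC)C(c1ccc([N+](=O)[O-])cc1)=NNC(=O)C2` and compound 4 `COc1cc2c(cc1OC)C(c1ccc(Cl)cc1)=NNC(=O)C2` share the other; the difference between the two cores is not broken down here. All were examined, or are to be examined, in a functional assay on the whole organism with Mus musculus as the target, in the rotarod test; on this read-out higher numbers stand for an effect only at larger amounts of compound and lower numbers for an effect already at smaller amounts.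

In this assay compound 1 gives only a limit, > 150 umol/kg. Compound 2, in this assay, gives 193 umol/kg. The step from compound 1 to compound 2, a step that the limit leaves unreadable from compound 1 to compound 2, cannot be sized due to the limit of > 150 umol/kg in this assay, at which 2 of the 3 values shown sit. The change behind that step is chloro in place of nitro on an aromatic carbon.

Compound 3 likewise gives only a limit in this assay, > 150 umol/kg. Compound 4 has not yet been measured in this assay. It differs from compound 3 by chloro in place of nitro on an aromatic carbon, which is the same change as that from compound 1 to compound 2, made on the other core.

With the earlier step unreadable, the expectation for compound 4 rests mainly on compound 2 and its value of 193 umol/kg after the same change. The step from compound 3 to compound 4 in this assay is estimated as a step that the limit leaves unreadable from compound 3 to compound 4. Compound 4 is therefore expected to give about 200 umol/kg in this assay, in a range from 100 umol/kg to 500 umol/kg, with a real chance that only a limit is reported again.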

Compound 4, dose for half-maximal effect: 240 umol/kg
Beside the measured number, compound 4's estimate is 1.2-fold (0.08 log units) below it; the range from low to high includes it.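

The step from compound 3 to compound 4 cannot be read in this assay, and the same holds for the matching step from compound 1 to compound 2, because one end of each step is a limit: the limit of > 150 umol/kg in this assay, at which 2 of the 4 values shown sit.

The compounds shown leave open how large the change from nitro to chloro is on either core, and whether it is the same on both.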